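A chloropyridyl ring returns to the thiazolidinone nitrogen

A few compounds are considered here, and "the series" means these few. Any claim that something is new, unique, unknown or untested is made for them only; others in the source may bear on it.

Measured compounds:
Compound 1, `O=C(NCCCCn1cccn1)c1cccc(C2SCC(=O)N2c2ccccn2)c1`: 60.3 nM
Compound 2, `CCOC(=O)c1sc(N2C(=O)CSC2c2cccc(C(=O)NCCCCn3cccn3)c2)nc1C`: 430 nM
Compound 3, `COc1ccccc1N1C(=O)CSC1c1cccc(C(=O)NCCCCc2cccs2)c1`: 46 nM

In a functional assay on HOS-TE85 cells (Homo sapiens) for inhibition, read by CCK-8 assay, with a stated time of 72 h (on this read-out lower numbers stand for stronger inhibition and higher numbers for weaker inhibition), compound 2 stands at the highest number of the three, so it is the weakest inhibitor shown; compound 1 sits at a lower number and compound 3 lower still. All three share a five-membered non-aromatic ring bearing a sulfur and an amide-type nitrogen, and they differ mainly in the group on that nitrogen and in the tail of the amide side chain.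

Compound 4, `O=C(NCCCCn1cccn1)c1cccc(C2SCC(=O)N2c2cc(Cl)ccn2)c1`, is not yet measured. It differs from compound 2 in one place: 4-chloropyridin-2-yl in place of 5-(ethoxycarbonyl)-4-methyl-1,3-thiazol-2-yl on an amide-type nitrogen in a ring. Going by the values given here, the only measured step that bears on this exchange is the one a 7.1-fold higher number from compound 1 to compound 2 (0.85 log units; beyond the scatter), which replaced a pyridin-2-yl with the thiazolyl ester and weakened inhibition. Compound 4 reverses that replacement, bringing in a pyridin-2-yl that carries a chlorine. Because of a 7.1-fold higher number from compound 1 to compound 2 (0.85 log units; beyond the scatter), a step back toward the number of compound 1 is expected, of roughly the same size and in the opposite direction, so a 6.1-fold lower number from compound 2 to compound 4 (0.79 log units; beyond the scatter) is the expected change. The estimate for compound 4 is 70 nM, with a range from 30 nM to 180 nM.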

Compound 4, half-maximal inhibitory concentration: 36.4 nM
Estimate against measurement, compound 4: 1.9-fold (0.28 log units) above, within the range that was stated.
By their numbers in this assay, from the lowest: compounds 4, 3 and 1 (each within the scatter of the next); then compound 2.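

In this assay, replacing 5-(ethoxycarbonyl)-4-methyl-1,3-thiazol-2-yl with 4-chloropyridin-2-yl on the amide-type nitrogen in the ring gives a 12-fold lower number from compound 2 to compound 4 (1.07 log units; beyond the scatter), so the loss seen with the thiazolyl ester does not persist once a substituted pyridin-2-yl group stands at this position. Putting chloro in place of hydrogen on an aromatic carbon gives a 1.7-fold lower number from compound 1 to compound 4 (0.22 log units; within the scatter), which lies within the scatter, so this position accepts the chlorine but the data show no gain from it, and the recovery is tied to the removal of the thiazolyl ester rather than to the chlorine. No measured evidence here explains why these groups give such different numbers.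

The compounds shown leave open whether a methoxy group, a trifluoromethyl group or an amine in place of the chloro on the pyridin-2-yl ring would keep a number like that of compound 4. They also leave open how 4-chloropyridin-2-yl would behave when paired with the different amide tail carried by compound 3.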